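Swapping a methoxy for a methyl on two fused cores

This account rests on a few compounds, and the source may have more. Where it says the series, first, only, none or still open, it means among the compounds named here.

Measured compounds:
compound 1 `CCC(=O)Oc1c(OC)c(OC)c(OC(=O)CC)c2c(OC)cccc12` — 3.44
compound 2 `COc1ccc2c(OC(C)=O)c(OC)c(OC)c(OC(C)=O)c2c1` — 2.39
compound 3 `CCC(=O)Oc1c(OC)c(OC)c(OC(=O)CC)c2c(C)cccc12` — 3.9

In a physicochemical assay for lipophilicity (on this read-out higher numbers stand for higher lipophilicity and lower numbers for lower lipophilicity), compound 1 and compound 3 share a core and differ in one place: methyl in place of methoxy on an aromatic carbon. This change made a step of a number 0.46 log units higher from compound 1 to compound 3 (beyond the scatter). Compound 2 has a different core; how the cores of compound 1 and compound 2 differ is not broken down here, and compound 2 sits lowest of the three, beyond the scatter from both.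

Compound 4 `COc1c(OC)c(OC(C)=O)c2cc(C)ccc2c1OC(C)=O` is not yet measured. It differs from compound 2 by methyl in place of methoxy on an aromatic carbon. The place is not word for word the same: in compound 3 the carbon is ortho to a fused ring and meta to a fused ring, whereas in compound 4 it is meta to a fused ring and para to a fused ring, so this is the same kind of change rather than the same one.

Because the single comparable case gave a number 0.46 log units higher from compound 1 to compound 3 (beyond the scatter), a similar step is expected here, a number 0.46 log units higher from compound 2 to compound 4 (beyond the scatter), so compound 4 is estimated at 2.85, between 2.5 and 3.2.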

Compound 4, partition coefficient: 2.86
Compound 4: the middle estimate sits 0.01 log units below what was measured; measured number inside the range.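

In this assay the swap of methoxy for methyl gave a number 0.47 log units higher from compound 2 to compound 4 (beyond the scatter) and, on the other core, a number 0.46 log units higher from compound 1 to compound 3 (beyond the scatter) as a step of the same modest kind, so the change carried over between these two cores even though its place on the ring is not the same. Two pairs show agreement in these compounds only and make no rule for other cores or places. No measurement shown explains why the step came out alike on both cores.

Methyl is the only group shown entering, so whether an amine or a carboxylic acid in its place would give a similar step stays open. From the compounds shown here alone, whether the step would hold on a third core also stays open.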